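A few compounds are considered here, and "the series" means these few. Any claim that something is new, unique, unknown or untested is made for them only; others in the source may bear on it.

Working notes on the series. In a functional assay on CHO-K1 cells for agonist activity at somatostatin receptor type 2 (Homo sapiens), read by cAMP accumulation, with a stated time of 30 min (on this read-out lower numbers stand for an effect already at smaller amounts and higher numbers for an effect only at larger amounts of compound), compound 1 `Cc1nc(C(=O)Nc2cncc(-c3cc(Cl)cc(Cl)c3)c2N2CCC(N)CC2)c(C)o1` gives 0.47 nM, compound 2 `Cc1cc(C)cc(-c2cncc(-c3nc4cc(Cl)ccc4[nH]3)c2N2CCC(N)CC2)c1` gives 0.015 nM and compound 3 `Cc1nn(C)cc1C(=O)Nc1cncc(-c2cc(Cl)cc(Cl)c2)c1N1CCC(N)CC1` gives 0.12 nM; compound 3 thus stands second of the three, with compound 2 showing the lowest number. Among the compounds with values here, the step of a 3.9-fold lower number from compound 1 to compound 3 (0.59 log units; beyond the scatter) is the only measured change at the carbonyl carbon. Compound 4 `Cc1cc(C(=O)Nc2cncc(-c3cc(Cl)cc(Cl)c3)c2N2CCC(N)CC2)n(C)n1` differs from compound 3 by 1,3-dimethyl-1H-pyrazol-5-yl in place of 1,3-dimethyl-1H-pyrazol-4-yl on a carbonyl carbon. Within the data shown here, no measured step tests this change; the one step at the same place, a 3.9-fold lower number from compound 1 to compound 3 (0.59 log units; beyond the scatter), was modest, so a step of at most modest size in this assay is expected, in either direction. Compound 4 is therefore estimated at 0.2 nM, range 0.06 nM to 0.7 nM, a step of a 1.7-fold higher number from compound 3 to compound 4 (0.22 log units; within the scatter) that is expected to stay near the scatter.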

Compound 4, half-maximal effective concentration: 0.041 nM
Compound 4: the middle estimate sits 4.9-fold (0.69 log units) above what was measured; measured number outside the range, below it.
By their numbers in this assay, from the lowest: compound 2; then compound 4; then compound 3; then compound 1.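

In this assay, the same atoms joined differently on the carbonyl carbon do not behave alike: moving from 1,3-dimethyl-1H-pyrazol-4-yl to 1,3-dimethyl-1H-pyrazol-5-yl gives a 2.9-fold lower number from compound 3 to compound 4 (0.47 log units; beyond the scatter) and so separates the two pyrazolyl groups. Against 2,5-dimethyl-1,3-oxazol-4-yl, the 1,3-dimethyl-1H-pyrazol-5-yl group gives an 11-fold lower number from compound 1 to compound 4 (1.06 log units; beyond the scatter), the largest step shown at this place. No available evidence accounts for either step. Open, on these data alone, is whether an ethyl or cyclopropyl group in place of either methyl on the 1,3-dimethyl-1H-pyrazol-5-yl group retains the number of compound 4, and how an unsubstituted phenyl on the carbonyl carbon compares.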